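The source may report more compounds than this note shows. Statements on the series, on what has been measured and on what is new or still open speak of the compounds shown alone.

Compound 1, `O=C(/C=C\c1cccc([N+](=O)[O-])c1)N1N=C(c2ccncc2)OC1c1c[nH]c2ccccc12`, gives > 30 ug/mL in an ADME assay on HeLa cells (Homo sapiens) for cytotoxicity, read by MTT assay, with a stated time of 72 h; a higher number here means a weaker inhibitor of growth, a lower number a stronger inhibitor of growth; this value is a limit of the assay, not a number.
Compound 2, `O=C(/C=C\c1ccccc1F)N1N=C(c2ccncc2)OC1c1c[nH]c2ccccc12`, gives > 30 ug/mL in this assay; this too is a limit.
Compound 3, `O=C(/C=C\c1ccccc1Cl)N1N=C(c2ccncc2)OC1c1c[nH]c2ccccc12`, gives > 30 ug/mL in this assay; again only a limit.

Compound 3 therefore stands where every measured compound stands: at the limit, as the limit of > 30 ug/mL in this assay, at which 3 of the 3 values shown sit, shows. None of the three measured steps can be read, because each joins two limits: a step that the two limits leave unreadable from compound 1 to compound 2, a step that the two limits leave unreadable from compound 1 to compound 3 and a step that the two limits leave unreadable from compound 2 to compound 3 are all of unreadable size.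

Compound 4, `O=C(/C=C\c1ccc(Cl)cc1Cl)N1N=C(c2ccncc2)OC1c1c[nH]c2ccccc12`, has not yet been measured. It differs from compound 3 by chloro in place of hydrogen on an aromatic carbon, the added chloro sitting on an aromatic carbon of a six-membered aromatic ring of carbon only, meta to a chloro group and para to a large group, so that 2-chlorophenyl becomes 2,4-dichlorophenyl.

Within the data shown here, no measured step bears directly on this change, and no measured step has a readable size. The expectation in this assay is therefore that compound 4 also sits at the limit, with the step from compound 3 expected to be a step that the limit leaves unreadable from compound 3 to compound 4. The estimate for compound 4 is 40 ug/mL, expected to fall between 15 ug/mL and 100 ug/mL, most likely reported only as a limit.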

Compound 4, concentration for 50% growth inhibition: 29.3 ug/mL
The estimate for compound 4 lay 1.4-fold (0.14 log units) above the measured number; the measured number falls inside the stated range.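

Compound 4 is the only compound shown that gives a number rather than a limit, which makes chloro in place of hydrogen on this aromatic carbon, para to a large group, the first change here with a readable lower bound: the limit of > 30 ug/mL in this assay, at which 3 of the 4 values shown sit. In this assay, among these compounds, turning 2-chlorophenyl into 2,4-dichlorophenyl gives an at least 1.0-fold lower number from compound 3 to compound 4 (0.01 log units; that floor lies within the scatter), so this change does not show a real gain in growth inhibition, only that the value has come within the range of the assay. The two wider swaps read the same way, with an at least 1.0-fold lower number from compound 2 to compound 4 (0.01 log units; that floor lies within the scatter) and an at least 1.0-fold lower number from compound 1 to compound 4 (0.01 log units; that floor lies within the scatter), while the steps among compounds 1, 2 and 3 still cannot be read.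

The compounds shown leave open how large any of these steps really is, since each one starts from a limit and only its floor can be given. They also leave open whether 4-chlorophenyl alone would give a number, and how bromo, methoxy or an amine on this same aromatic carbon would compare with chloro.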